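The compounds below may be only part of what the source reports. "The series", "measured", "known", "first", "only" and "open" are said of these compounds alone.

Compound 1 `Nc1ccc(S(=O)(=O)N2CCN(c3ncc(C(O)(C(F)(F)F)C(F)(F)F)cc3C3CC3)CC2)cn1` gave 38 mL.min-1.g-1
Compound 2 `CS(=O)(=O)Nc1cccc(-c2cc(C(O)(C(F)(F)F)C(F)(F)F)cnc2N2CCN(S(=O)(=O)c3ccc(N)nc3)CC2)c1` gave 40 mL.min-1.g-1

Within the data shown here, in an ADME assay (liver) for metabolic stability, with Liver microsome (Homo sapiens) as the target, using microsomes and NADPH, with a stated time of 30 min, tested at 1 uM (a higher number here means faster removal of the compound, a lower number slower removal), compound 2 gives 40 mL.min-1.g-1, the higher of the two numbers measured so far, though the gap to compound 1 is within the scatter. Compound 3 `Nc1ccc(S(=O)(=O)N2CCN(c3ncc(C(O)(C(F)(F)F)C(F)(F)F)cc3-c3ccc4ocnc4c3)CC2)cn1` differs from compound 2 in one place: 1,3-benzoxazol-5-yl in place of 3-(methanesulfonamido)phenyl on an aromatic carbon. Among the measured compounds shown here, the only measured step that bears on this is a 1.1-fold higher number from compound 1 to compound 2 (0.02 log units; within the scatter), which shows that exchanging the group at this very position left the number essentially unchanged. For the measured compounds named here, no measured compound carries the 1,3-benzoxazol-5-yl group, so nothing shows how it behaves. Going by the values given here, with the step from compound 1 to compound 2 as the sole guide, no step beyond the scatter is expected for compound 3, and the estimate for the step from compound 2 to compound 3 is a 1.1-fold higher number from compound 2 to compound 3 (0.05 log units; within the scatter). Compound 3 is therefore expected to give about 45 mL.min-1.g-1 in this assay, with a range of 20 mL.min-1.g-1 to 100 mL.min-1.g-1.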

Compound 3, intrinsic clearance in microsomes: < 14 mL.min-1.g-1
Compound 3: only a limit was reported; the forecaster's own chance of this, stated with the estimate: 5%; at least 3.2-fold (0.50 log units) between middle value and limit.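

Compounds 1 and 2 lie within the scatter of each other, so the position could have seemed indifferent to the group placed there, but this assay shows otherwise. Placing 1,3-benzoxazol-5-yl on this aromatic carbon gives an at least 2.8-fold lower number from compound 2 to compound 3 (0.45 log units; beyond the scatter), and measured against cyclopropyl the same group gives an at least 2.7-fold lower number from compound 1 to compound 3 (0.43 log units; beyond the scatter). The value of compound 3 is a limit and not a number: the limit of < 14 mL.min-1.g-1 in this assay, at which 1 of the 3 values shown sits.

The compounds shown do not tell whether the lower number belongs to the whole 1,3-benzoxazol-5-yl group or to one of its two rings. As far as these compounds go, an unsubstituted phenyl ring or a 4-methoxyphenyl group at this position could begin to separate these possibilities, and how far compound 3 lies past its limit stays open.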